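Hydroxyalkyl chain length in a myeloperoxidase inhibitor series

The source may report more compounds than this note shows. Statements on the series, on what has been measured and on what is new or still open speak of the compounds shown alone.

Measured so far, in an assay on isolated protein (urine) for inhibition of Myeloperoxidase (Homo sapiens), read by spectrophotometry; on this read-out lower numbers stand for stronger inhibition and higher numbers for weaker inhibition:
compound 1, `COc1c2ccccc2nn1CCCCO`, gives 1790 nM
compound 2, `COc1c2ccccc2nn1CCCCCO`, gives 1540 nM
compound 3, `O=c1c2ccccc2[nH]n1CCO`, gives 2470 nM

Compounds 1 and 2 share a core and differ in one place, (hydroxymethyl in place of hydroxy on a saturated chain carbon, four bonds along the chain from an aromatic nitrogen). The step that this change made is a 1.2-fold lower number from compound 1 to compound 2 (0.07 log units; within the scatter), so on this read-out the two compounds cannot be told apart. Compound 3 carries a different core; the difference between the two cores is not broken down here. Its number in this assay lies within the scatter of both compound 1 and compound 2, so no order among the three is claimed.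

Compound 4, `O=c1c2ccccc2[nH]n1CCCO`, is not yet measured. It differs from compound 3 by hydroxymethyl in place of hydroxy on a saturated chain carbon, two bonds along the chain from an aromatic nitrogen. This is the same kind of change as that from compound 1 to compound 2, but not the same: there the place was four bonds along the chain from an aromatic nitrogen, here it is two bonds along the chain from an aromatic nitrogen, and the core is that of compound 3 rather than of compound 1. Among the measured compounds shown here, with only one earlier example of this kind of change, the expectation rests on it: the step from compound 3 to compound 4 is estimated as a 1.2-fold lower number from compound 3 to compound 4 (0.07 log units; within the scatter), because from compound 1 to compound 2 the change gave a 1.2-fold lower number from compound 1 to compound 2 (0.07 log units; within the scatter). On that basis compound 4 is estimated to give about 2100 nM in this assay, expected to fall between 1000 nM and 4500 nM.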

Compound 4, half-maximal inhibitory concentration: 1950 nM
Compound 4: middle estimate off by 1.1-fold (0.03 log units), on the high side; the range from low to high includes it.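

In this assay, hydroxymethyl in place of hydroxy on a saturated chain carbon, two bonds along the chain from an aromatic nitrogen, gives a 1.3-fold lower number from compound 3 to compound 4 (0.10 log units; within the scatter), so on this read-out the two compounds cannot be told apart. Set beside the earlier example, the step on the core of compound 3 does not differ from the step on the core of compound 1: the same change on two cores in this assay, a 1.2-fold lower number (0.07 log units; within the scatter) from compound 1 to compound 2 and a 1.3-fold lower number (0.10 log units; within the scatter) from compound 3 to compound 4, 1.1-fold (0.04 log units) apart, within the scatter of two such steps This shows that the change leaves the number within the scatter on both cores and at both places on the chain, but with no step beyond the scatter it does not show that a measurable effect carries from one core to the other.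

The compounds shown leave open whether a longer chain, or an amine or a carboxylic acid in place of hydroxy, would give a step beyond the scatter on either core. Among the compounds shown here, they also leave open how the two cores compare at equal chain length, since no pair here carries the same chain on both cores.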